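The source may hold more compounds than are shown below. What is called first, only, known or untested is meant among the compounds shown, and "the series" means these compounds.

Compound 1 `O=C(CN(c1ncnc2c1ncn2C1CCCCO1)C1CC1)NCC(=O)OCc1ccccc1` gives 17.2% in a functional assay on the whole organism (Tail, strain ICR) with Mus musculus as the target, in the tail flick test, with a stated time of 120 min, at a dose of 25 umol/kg by the oral route; a lower number here means a weaker effect, a higher number a stronger effect of the compound at the dose given.
Compound 2 `C[C@@H](O)[C@H](NC(=O)CN(c1ncnc2c1ncn2C1CCCCO1)C1CC1)C(=O)OCc1ccccc1` gives 10.9% in this assay.

For the measured compounds named here, compound 2 stands lowest of the two numbers so far, with compound 1 nearest; the step of a number 6.3 percentage points lower from compound 1 to compound 2 (within the scatter) lies within the scatter, so the two read-outs cannot be told apart. Compound 3 `C[C@H](NC(=O)CN(c1ncnc2c1ncn2C1CCCCO1)C1CC1)C(=O)OCc1ccccc1` is to be measured in this assay. The change from compound 2 is methyl in place of 1-hydroxyethyl on a saturated chain carbon bound to an amide-type nitrogen and a carbonyl carbon. Going by the values given here, the only measured step that bears on this site is the one from compound 1 to compound 2, where 1-hydroxyethyl entered in place of hydrogen and the number moved by a number 6.3 percentage points lower from compound 1 to compound 2 (within the scatter), within the scatter. Methyl sits between hydrogen and 1-hydroxyethyl in what it carries at this carbon, and neither end of that range gave a distinguishable read-out, so no step beyond the scatter is expected for a number 3.1 percentage points higher from compound 2 to compound 3 (within the scatter). Compound 3 is estimated at 14%, with a range from 3% to 28%.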

Compound 3, a percentage reported as activity, at one dose (the size of the read-out at that dose, not a potency): 25.3%
Beside the measured number, compound 3's estimate is 11.3 percentage points below it, and the stated range covers the measured number.
By their numbers in this assay, from the lowest: compounds 2, 1 and 3 (each within the scatter of the next, the first and the last beyond it).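

For the compounds shown here, at the saturated chain carbon bound to an amide-type nitrogen and a carbonyl carbon, methyl in place of 1-hydroxyethyl gives the first step in this assay that lies beyond the scatter (a number 14.4 percentage points higher from compound 2 to compound 3 (beyond the scatter)). Methyl in place of hydrogen stays within the scatter (a number 8.1 percentage points higher from compound 1 to compound 3 (within the scatter)), so at this position only methyl and 1-hydroxyethyl can be told apart, while hydrogen cannot be separated from either. Nothing available explains this difference.

Still open, going by these compounds, is whether a longer chain such as ethyl, or an amine or a carboxylic acid on this carbon, would separate from methyl, and whether the hydroxyl of 1-hydroxyethyl alone accounts for the step. With one dose and one time point, the read-outs also leave potency across the series undefined.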